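An aryl swap on the four-membered ring

This account rests on a few compounds, and the source may have more. Where it says the series, first, only, none or still open, it means among the compounds named here.

In a functional assay on MDA-MB-231 cells (Homo sapiens) for antiproliferative activity, read by MTT assay, with a stated time of 48 h (on this read-out higher numbers stand for weaker inhibition and lower numbers for stronger inhibition), the measured compounds read as follows
Compound 1 (`CCOC(=O)/C(=C/c1ccccc1)CN1C(=O)[C@@H](OC)[C@H]1c1ccc(Cl)cc1`) gives 11100 nM
Compound 2 (`CCOC(=O)/C(=C/c1ccccc1)CN1C(=O)[C@@H](OC)[C@H]1c1cccc([N+](=O)[O-])c1`) gives 14400 nM

For the measured compounds named here, compound 2 stands level with compound 1 on these numbers, and the one measured step (a 1.3-fold higher number from compound 1 to compound 2 (0.11 log units; within the scatter)) lies within the scatter. Compound 3 (`CCOC(=O)/C(=C/c1ccccc1)CN1C(=O)[C@@H](OC)[C@H]1c1ccccc1Br`) carries 2-bromophenyl in place of 3-nitrophenyl on a saturated ring carbon. Going by the values given here, the measured step changed the group on this same carbon, though no 2-bromophenyl compound has a value yet. No step beyond the scatter is therefore expected in this assay in either direction. The estimated change is a 1.2-fold lower number from compound 2 to compound 3 (0.06 log units; within the scatter) at most modest. For compound 3 the estimate is 12500 nM within an expected range of 5500 nM to 28000 nM in this read-out.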

Compound 3, half-maximal inhibitory concentration: 6860 nM
Beside the measured number, compound 3's estimate is 1.8-fold (0.26 log units) above it, and the stated range covers the measured number.
By their numbers in this assay, from the lowest: compounds 3, 1 and 2 (each within the scatter of the next, the first and the last beyond it).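

In this assay the aryl group on this saturated ring carbon, next to the ring nitrogen, now shows its first step beyond the scatter, as 2-bromophenyl in place of 3-nitrophenyl gives a 2.1-fold lower number from compound 2 to compound 3 (0.32 log units; beyond the scatter) and that step is modest. In place of 4-chlorophenyl the same group gives a 1.6-fold lower number from compound 1 to compound 3 (0.21 log units; within the scatter) and stays within the scatter, so only the widest gap among these compounds clears it. Nothing measured here gives a reason for this step.

Still open, from the compounds shown here alone, is whether a 4-bromophenyl group would read like 2-bromophenyl, and how an aminophenyl or a plain phenyl group on this carbon would read.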